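A few compounds are considered here, and "the series" means these few. Any claim that something is new, unique, unknown or untested is made for them only; others in the source may bear on it.

Measured compounds:
- compound 1, `COc1cc(OC)cc(N2CCN(C(=O)c3onc(C)c3-c3ccccc3)CC2)c1`: in a functional assay on HL-60 cells (Homo sapiens) for inhibition, read by MTT assay, with a stated time of 72 h (on this read-out lower numbers stand for stronger inhibition and higher numbers for weaker inhibition), compound 1 gives 152 nM
- compound 2, `COc1cc(OC)cc(N2CCN(C(=O)c3oc(C)nc3-c3cccc(F)c3)CC2)c1`: in this assay compound 2 gives 28.2 nM
- compound 3, `Cc1nc(-c2ccccc2)c(C(=O)N2CCN(c3ccc(C(F)(F)F)cc3)CC2)o1`: in this assay compound 3 gives only a limit, > 1000 nM

Among the two numbers that are not limits, compound 1 has the higher one; compound 2 sits at a lower number, and the gap between the two is beyond the usual scatter. The value for compound 3 is a limit of this assay and not a number; one of the three values sits at that limit (the limit of > 1000 nM in this assay, at which 1 of the 3 values shown sits). Within the data shown here, no step between two measured compounds that differ in a single place is available here, so the effect of any single change on this read-out cannot be taken from the measured set.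

Compound 4, `COc1cc(OC)cc(N2CCN(C(=O)c3onc(C)c3-c3ccc(-c4ccco4)cc3)CC2)c1`, differs from compound 1 in one place:
furan-2-yl in place of hydrogen on an aromatic carbon
The change leaves the shared core and the amide untouched and enlarges the aryl group on the five-membered ring. Among the measured compounds shown here, with no measured step of this kind, the expectation for the step from compound 1 to compound 4 is of a small size in this assay, a 1.3-fold lower number from compound 1 to compound 4 (0.10 log units; within the scatter), with the direction uncertain. For compound 4 the estimated value in this assay is 120 nM, expected to lie between 40 nM and 400 nM.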

Compound 4, half-maximal inhibitory concentration: 191 nM
Compound 4: the middle estimate sits 1.6-fold (0.20 log units) below what was measured; measured number inside the range.
By their numbers in this assay, from the lowest: compound 2; then compounds 1 and 4 (each within the scatter of the next). At a limit, above all of these: compound 3.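

In this assay, among these compounds, furan-2-yl in place of hydrogen on an aromatic carbon, para to a large group, gives a 1.3-fold higher number from compound 1 to compound 4 (0.10 log units; within the scatter); this is the only single-place step so far. The aryl group on the five-membered ring can therefore go from phenyl to 4-(furan-2-yl)phenyl, adding 5 heavy atoms and one five-membered aromatic ring, without a step beyond the scatter on this read-out, though this shows it for one group at one place only. Nothing measured here accounts for the size of this step.

Steps from compound 2 and compound 3 to the other compounds cannot be read, as each differs from them in more than one place, so the contributions of the five-membered ring, the fluorine and the aryl group on the piperazine side remain unseparated. Also open, as far as these compounds go, is whether an aminomethyl group, a carboxylic acid or a thiophen-2-yl group at the same place on the phenyl ring would keep the read-out as close to that of compound 1 as furan-2-yl does.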